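Trimming the biaryl of compound 3 to a methoxy group

The source may report more compounds than this note shows. Statements on the series, on what has been measured and on what is new or still open speak of the compounds shown alone.

Three compounds share a piperidinylpiperidine sulfonamide core and differ only in the aryl group on the sulfonyl sulfur. In a functional assay on DLD-1 cells (Homo sapiens) for antiproliferative activity, read by CellTiter-Glo, with a stated time of 72 h (on this read-out lower numbers stand for stronger inhibition and higher numbers for weaker inhibition), compound 1 `CC1CCN(C2CCN(S(=O)(=O)c3cccnc3)CC2)CC1` gives 2400 nM, while compound 2 `CC1CCN(C2CCN(S(=O)(=O)c3ccccc3Br)CC2)CC1` gives 3 nM, a change of an 800-fold lower number from compound 1 to compound 2 (2.90 log units; beyond the scatter). Compound 3 `CC1CCN(C2CCN(S(=O)(=O)c3cccc(-c4ccc(F)cc4)c3)CC2)CC1` gives 12 nM in this assay and therefore stands between the two, closer to compound 2 than to compound 1.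

Compound 4 `COc1cccc(S(=O)(=O)N2CCC(N3CCC(C)CC3)CC2)c1` keeps the core of compound 3 and carries the change (methoxy in place of 4-fluorophenyl on an aromatic carbon). Among the compounds with values here, no measured step exchanges one substituent on the same aryl ring for another: the only step, from compound 1 to compound 2, swaps the whole aryl group, so it shows that this assay can move strongly with the sulfonyl aryl group but does not speak to this trimming. With a much smaller group in place of the aryl, compound 4 is expected to give a higher number, estimated at 150 nM with a range from 30 nM to 800 nM, a step of a 13-fold higher number from compound 3 to compound 4 (1.10 log units; beyond the scatter).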

Compound 4, half-maximal inhibitory concentration: > 5000 nM
Compound 4: only a limit was reported; the forecaster's own chance of this, stated with the estimate: 2%; middle value at least 33-fold (1.52 log units) from the limit.
By their numbers in this assay, from the lowest: compound 2; then compound 3; then compound 1. At a limit, above all of these: compound 4.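

Compound 4 is reported only as a limit and not as a number: the limit of > 5000 nM in this assay, at which 1 of the 4 values shown sits. Trimming 4-fluorophenyl to methoxy gives an at least 410-fold higher number from compound 3 to compound 4 (2.61 log units; beyond the scatter) in this assay, so a change to a single substituent on the aryl ring can move this read-out strongly, which the earlier swap of the whole aryl group could not show. As a sulfonyl aryl group, 3-methoxyphenyl also lies far from 2-bromophenyl, with an at least 1600-fold higher number from compound 2 to compound 4 (3.22 log units; beyond the scatter), and even past pyridin-3-yl, with an at least 2.0-fold higher number from compound 1 to compound 4 (0.31 log units; beyond the scatter).

The compounds shown leave open whether the loss follows the departure of the aromatic ring or the arrival of the methoxy group. A plain phenyl, a small alkyl group such as methyl, or an amine on the same aromatic carbon would separate these two readings.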